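The compounds below may be only part of what the source reports. "The series", "measured", "known", "first", "only" and "open" are said of these compounds alone.

Measured in a functional assay on MDA-MB-231 cells (Homo sapiens) for cytotoxicity, read by MTT assay, with a stated time of 48 h; on this read-out lower numbers stand for stronger inhibition and higher numbers for weaker inhibition:
- compound 1 `Cn1cccc1C(=O)/C=C/c1ccc2c(c1)B(O)OC2`: > 100000 nM, a limit of this assay, not a number
- compound 2 `Cc1ccc(C(=O)/C=C/c2ccc3c(c2)B(O)OC3)cc1`: 6500 nM

Among the measured compounds shown here, compound 2 carries the only real number in this assay; the other value shown is a limit (the limit of > 100000 nM in this assay, at which 1 of the 2 values shown sits). Compound 3 `Cc1ccc(C(=O)/C=C/c2ccc3c(c2)B(O)OC3)cc1C` differs from compound 2 by methyl in place of hydrogen on an aromatic carbon. For the measured compounds named here, the only measured step, an at least 15-fold lower number from compound 1 to compound 2 (1.18 log units; beyond the scatter), swaps the group on the carbonyl carbon and leaves the phenyl ring untouched, so it says nothing direct about adding a second methyl to that ring. Going by the values given here, with no step of the same kind to lean on, the change is treated as a minor addition to an already methylated ring, and no step beyond the scatter is expected in this assay in either direction. Compound 3 is therefore expected to give about 5000 nM, within a range of 1500 nM to 20000 nM. The expected step of a 1.3-fold lower number from compound 2 to compound 3 (0.11 log units; within the scatter) lies within the scatter.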

Compound 3, half-maximal inhibitory concentration: 5300 nM
Estimate against measurement, compound 3: 1.1-fold (0.03 log units) below; low and high end bracket the measured number.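

In this assay the added methyl gives a 1.2-fold lower number from compound 2 to compound 3 (0.09 log units; within the scatter) and so leaves the number within the scatter. Among the compounds shown here, this aromatic carbon, ortho to a methyl group and meta to a large group, therefore accepts one extra carbon without a measurable change in this cytotoxicity read-out, and this is the first information on the phenyl ring itself, since the earlier step changed only the group on the carbonyl carbon. Nothing among the data shown gives a reason for this flat result.

As far as these compounds go, whether this position would accept a group other than methyl, such as an amine, a carboxylic acid or a longer chain, stays open. Also open, from the compounds shown here alone, is whether a methyl here would behave the same way without the existing methyl on the ring.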